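A Chloro Group Added to Compound 2

This account rests on a few compounds, and the source may have more. Where it says the series, first, only, none or still open, it means among the compounds named here.

Of the compounds shown here, two have so far been tested in a functional assay on KB cells (Homo sapiens) for inhibition, read by MTT assay, with a stated time of 24 h, tested at 10 ug/mL; a lower number here means less inhibition of growth, a higher number more inhibition of growth at the concentration tested. In this assay, compound 1 `O=C(CCCCC(S)CCS)Nc1ccc(Cl)cc1` gives 18.2%, and compound 2 `O=C(CCCCC(CCSC(=O)c1ccccc1)SC(=O)c1ccccc1)Nc1ccccc1` gives 2.67%. Compound 2 therefore stands lower of the two, and the gap between them lies beyond the scatter. The two structures differ in more than one place, so the gap cannot be assigned to any single feature.

Compound 3 `O=C(CCCCC(CCSC(=O)c1ccccc1)SC(=O)c1ccccc1)Nc1cccc(Cl)c1` is compound 2 with chloro in place of hydrogen on an aromatic carbon, meta to a large group: chloro in place of hydrogen on an aromatic carbon. Among the measured compounds shown here, no measured pair isolates this change. Compound 1, at 18.2%, also carries a chloro group, but its other structural differences make it only weak guidance. A modest upward shift in this assay is the most that this comparison supports. The expected change, a number 4.3 percentage points higher from compound 2 to compound 3 (within the scatter), is a small rise estimated to stay within the scatter. For compound 3 the estimated value is 7%, with an expected range of 1% to 16%.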

Compound 3, percent growth inhibition at one concentration: 16.6%
Compound 3: middle estimate off by 9.6 percentage points, on the low side, and the stated range ends below it.
By their numbers in this assay, from the lowest: compound 2; then compounds 3 and 1 (each within the scatter of the next).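

Among the compounds shown here, with this pair, a single change can be read for the first time: in this assay, chloro in place of hydrogen on an aromatic carbon, meta to a large group, gives a number 13.9 percentage points higher from compound 2 to compound 3 (beyond the scatter). The earlier compounds shown here differed in more than one place and could not show this, whereas here the rest of the structure stays the same and the one added heavy atom, a chlorine, is enough to carry the read-out beyond the scatter. No measurement shown here bears on why this chloro group has that effect.

The compounds shown leave open whether this step is specific to chloro, since a bromo, methyl or methoxy group in the same place does not appear among them, and whether it depends on this place on the ring. They also leave open whether the same change would matter in a compound with free thiol groups like those of compound 1, which differs from the others in more than one place and so cannot answer that.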